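Swapping a Thiazole for a Pyridine on the Amide Nitrogen

The source may report more compounds than this note shows. Statements on the series, on what has been measured and on what is new or still open speak of the compounds shown alone.

Of the compounds shown here, two have so far been tested in a physicochemical assay for solubility, read by nephelometry, measured as kinetic solubility, at pH 2.0; a higher number here means a more soluble compound, a lower number a less soluble compound. Compound 1 `NCc1csc(NC(=O)c2cc3ccccc3[nH]2)n1` comes out at > 100 ug/mL, which is a limit of the assay rather than a number. Compound 2 `Cc1csc(NC(=O)c2cc(C(C)(C)C)nn2Cc2ccccc2)n1` gives < 1.6 ug/mL, again only a limit of the assay and not a number, as the limit of < 1.6 ug/mL in this assay, at which 1 of the 2 values shown sits, shows. On the two results in hand, compound 2 therefore stands at the poorly soluble end. Compound 3 `CC(C)(C)c1cc(C(=O)Nc2ccccn2)n(Cc2ccccc2)n1` differs from compound 2 in one place: pyridin-2-yl in place of 4-methyl-1,3-thiazol-2-yl on an amide-type nitrogen. Within the data shown here, no measured pair shows what such a change does to solubility, so the direction of the step rests on little. The expected change is an at least 1.8-fold higher number from compound 2 to compound 3 (0.27 log units; that floor lies within the scatter), a small rise that may well stay within the usual scatter. For compound 3 the solubility is estimated at 3 ug/mL, with a range from 1 ug/mL to 15 ug/mL, and a fair chance that only a limit is reported once more.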

Compound 3, solubility: 25 ug/mL
For compound 3 the middle estimate is 8.3-fold (0.92 log units) below the measured one, outside the stated range (above it).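

In this assay, pyridin-2-yl in place of 4-methyl-1,3-thiazol-2-yl on an amide-type nitrogen gives an at least 15-fold higher number from compound 2 to compound 3 (1.19 log units; beyond the scatter), the first measured sign that the group at this place can move the reading beyond the scatter. That size is only a floor, and the full step may be larger, since compound 2 sits at a limit of the assay and not at a number: the limit of < 1.6 ug/mL in this assay, at which 1 of the 3 values shown sits.

Compound 3 gives 25 ug/mL, a true number, so later changes at this place can be read against it in either direction.

One pair cannot separate the roles of the methyl, the sulfur and the ring size, and a plain phenyl on this nitrogen, or an amine on the pyridine, would test them further. From the compounds shown here alone, whether the step holds on a different core also stays open, as compound 1 differs from both other compounds in more than one place.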